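Fluoro for methoxy on the amidine-bearing biaryl thiophene series

This account rests on a few compounds, and the source may have more. Where it says the series, first, only, none or still open, it means among the compounds named here.

The study follows a set of amidine-bearing compounds sharing one core. Compound 1 `COc1ccc(-c2ccc(-c3ccc(C(=N)N)cc3)s2)cc1` was tested in a functional assay on SK-MEL-28 cells (Homo sapiens) for inhibition, read by sulforhodamine B assay, with a stated time of 48 h (on this read-out higher numbers stand for weaker inhibition of growth and lower numbers for stronger inhibition of growth), where compound 1 gives 1550 nM. Its companion, compound 2 `N=C(N)c1ccc(-c2ccc(-c3cc(Cl)cc(Cl)c3)s2)cc1`, gives 1710 nM in this assay. Of these two numbers compound 1 has the lowest, and the nearest, that of compound 2, lies within the scatter, so the two cannot be ordered.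

Compound 3 `N=C(N)c1ccc(-c2ccc(-c3ccc(F)cc3)s2)cc1` is not yet measured. It differs from compound 1 by fluoro in place of methoxy on an aromatic carbon. Since both measured compounds sit close together in this assay, the step from a small substituent swap is expected to be modest. The step of a 1.2-fold higher number from compound 1 to compound 3 (0.06 log units; within the scatter) is expected to be small, with no clear direction beyond the scatter. Compound 3 is therefore estimated at 1800 nM in this assay, within a range from 800 nM to 4000 nM.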

Compound 3, concentration for 50% growth inhibition: 1570 nM
The estimate for compound 3 lay 1.1-fold (0.06 log units) above the measured number, within the range that was stated.
By their numbers in this assay, from the lowest: compounds 1, 3 and 2 (each within the scatter of the next).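

In this assay, fluoro in place of methoxy on this aromatic carbon, para to a large group, gives a 1.0-fold higher number from compound 1 to compound 3 (0.01 log units; within the scatter), so the change cannot be told apart from the scatter of repeated measurements. Methoxy carries 1 hydrogen-bond acceptor and fluoro carries 0 hydrogen-bond acceptors, yet the read-out does not separate the two groups at this position. No measurement available here bears on why the two groups read alike.

The compounds shown leave open whether an amine, a carboxylic acid or a longer chain such as butoxy on this carbon would also stay within the scatter of compound 1. From the compounds shown here alone, whether the same change made elsewhere on the shared core would read alike also remains open.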